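From Propargyl to 4-Phenylphenyl on an Ester Chain

The source may report more compounds than this note shows. Statements on the series, on what has been measured and on what is new or still open speak of the compounds shown alone.

Of the compounds shown here, three sharing one core have been measured in a functional assay on HEK293 cells for antagonist activity at Voltage-dependent L-type calcium channel subunit alpha-1D (Rattus norvegicus), read by FLIPR; on this read-out lower numbers stand for stronger inhibition and higher numbers for weaker inhibition. Compound 1 `CCCCC1=C(C(=O)OCC)C(c2cccc([N+](=O)[O-])c2)C(C(=O)OCC)=C(C)N1` gives 20 nM in this assay. Compound 2 `C#CCCOC(=O)C1=C(C)NC(C)=C(C(=O)OC)C1c1cccc([N+](=O)[O-])c1` gives 35 nM in this assay, and compound 3 `CCOC(=O)C1=C(C)NC(C)=C(C(=O)OCCOC)C1c1cccc([N+](=O)[O-])c1` gives 82 nM in this assay. Among these three numbers compound 2 stands second highest. Its nearest neighbour is compound 1, whose value differs from it by an amount within the usual scatter, so no order can be drawn between those two, while compound 3 gives the number furthest from it, beyond the scatter.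

Compound 4 `COC(=O)C1=C(C)NC(C)=C(C(=O)OCc2ccc(-c3ccccc3)cc2)C1c1cccc([N+](=O)[O-])c1` has not yet been measured. It differs from compound 2 at one place: 4-phenylphenyl in place of propargyl on a saturated chain carbon bound to an oxygen next to a carbonyl group. The ester chain thus loses the propargyl with its triple bond and gains two six-membered aromatic rings of carbon only, on a saturated chain carbon bound to an oxygen next to a carbonyl group. Within the data shown here, no measured pair in this set shows a change of this kind, so the size of the step cannot be read from the data; the three measured esters differ in their chains and yet fall within a narrow band.

In this assay compound 4 is expected to give 55 nM, with a likely range from 12 nM to 250 nM. The step of a 1.6-fold higher number from compound 2 to compound 4 (0.20 log units; within the scatter) that this estimate implies is expected to be small, perhaps a slight weakening, and may not exceed the scatter.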

Compound 4, half-maximal inhibitory concentration: 74 nM
The estimate for compound 4 lay 1.3-fold (0.13 log units) below the measured number; low and high end bracket the measured number.
By their numbers in this assay, from the lowest: compounds 1 and 2 (each within the scatter of the next); then compounds 4 and 3 (each within the scatter of the next).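

In this assay, the place on a saturated chain carbon bound to an oxygen next to a carbonyl group now has its first measured change, and the result is a 2.1-fold higher number from compound 2 to compound 4 (0.33 log units; beyond the scatter), a modest step that lies beyond the usual scatter. Replacing propargyl, with 3 heavy atoms and a triple bond, by 4-phenylphenyl, with 12 heavy atoms and two six-membered aromatic rings of carbon only, therefore weakens inhibition, but only modestly, so this place tolerates a substantial change of group without a large loss on this read-out. The compounds shown offer no evidence on the cause of this step.

This single step cannot separate the contribution of the two aromatic rings from the loss of the triple bond, and a lone phenyl ring at the same place would be needed to show whether one ring gives a number nearer that of compound 2 or of compound 4. Going by these compounds, it also remains open how a group of a different kind, such as an amine or a carboxylic acid at the end of a longer chain, would fare at this place.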